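Quinazoline series: methyl to trifluoromethyl, second position

A few compounds are considered here, and "the series" means these few. Any claim that something is new, unique, unknown or untested is made for them only; others in the source may bear on it.

Measured compounds:
compound 1 `Cc1ccc(CNc2nc(Nc3cc(C)[nH]n3)c3ccccc3n2)cc1` gives 110 nM
compound 2 `Cc1cc(Nc2nc(NCc3ccc(C(F)(F)F)cc3)nc3ccccc23)n[nH]1` gives 1400 nM
compound 3 `Cc1ccc2c(Nc3cc(C)[nH]n3)nc(NCc3ccc(F)cc3F)nc2c1` gives 27 nM

All values come from an assay for inhibition of high affinity nerve growth factor receptor (Homo sapiens), read by HTRF, with a stated time of 30 min, in the presence of a further agent that is not named here; a higher number here means a weaker inhibitor, a lower number a stronger inhibitor. Compound 3 stands lowest of the three, beyond the scatter against both others.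

Compound 1 and compound 2 differ in one place, (trifluoromethyl in place of methyl on an aromatic carbon). The step in this assay is a 13-fold higher number from compound 1 to compound 2 (1.10 log units; beyond the scatter). The change sits on an aromatic carbon of a six-membered aromatic ring of carbon only, para to a large group.

Compound 4 `Cc1cc(Nc2nc(NCc3ccc(F)cc3F)nc3cc(C(F)(F)F)ccc23)n[nH]1` is not yet measured. It differs from compound 3 in one place, (trifluoromethyl in place of methyl on an aromatic carbon). Here the place is on a six-membered aromatic ring of carbon only that is part of a fused or bridged system of two rings, meta to a fused ring and para to a fused ring. The two place descriptions are not the same, so this is the same kind of change as from compound 1 to compound 2, not the same change. The difference between the core of compound 1 and the core of compound 3 is not broken down here.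

Going by the values given here, the only measured precedent is the large upward step a 13-fold higher number from compound 1 to compound 2 (1.10 log units; beyond the scatter). Because of that step, compound 4 is expected to give a higher number than compound 3, and since the place differs, a smaller step is estimated: a 3.7-fold higher number from compound 3 to compound 4 (0.57 log units; beyond the scatter). Compound 4 is expected to give about 100 nM in this assay, with a range from 35 nM to 400 nM.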

Compound 4, half-maximal inhibitory concentration: 57 nM
Compound 4: the middle estimate sits 1.8-fold (0.24 log units) above what was measured, within the range that was stated.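

Trifluoromethyl in place of methyl gives a higher number in this assay in both pairs, and the new step, a 2.1-fold higher number from compound 3 to compound 4 (0.32 log units; beyond the scatter), keeps the direction of the earlier one, but the size of the step does not carry over from one core to the other: the same change on two cores in this assay, a 13-fold higher number (1.10 log units; beyond the scatter) from compound 1 to compound 2 and a 2.1-fold higher number (0.32 log units; beyond the scatter) from compound 3 to compound 4, 6.0-fold (0.78 log units) apart, beyond the scatter of two such steps

This shows that the step size cannot simply be transferred within the series, and that a large penalty in one pair does not foretell a large penalty in the other. It does not show what sets the gap, since the change stands at a different place in each pair and the two cores also differ elsewhere, and these pairs do not separate those contributions. Two pairs also give no rule for any further core.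

Still open, going by these compounds, is how the same change behaves when both places are compared on one shared core, which would separate place from core. Also open, on these data alone, is whether a chlorine atom, a methoxy group or an amine at either place would follow trifluoromethyl or methyl in this assay.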